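Lactam N-aryl change in a metabotropic glutamate receptor 5 modulator series

The source may report more compounds than this note shows. Statements on the series, on what has been measured and on what is new or still open speak of the compounds shown alone.

Compound 1, `O=C1CC(c2nc(-c3cccc(Cl)c3)no2)CN1c1ccc(Cl)c(Cl)c1`: 460 nM
Compound 2, `Cc1ccc(N2CC(c3nc(-c4cccc(F)c4)no3)CC2=O)cc1`: 1200 nM
Compound 3, `O=C1CC(c2nc(-c3cccc(F)c3)no2)CN1c1ccc(F)cc1`: 88 nM

Going by the values given here, in an in vitro functional assay on HEK293-A cells for positive allosteric modulation of metabotropic glutamate receptor 5 (Homo sapiens), read by FLIPR and calcium flux (on this read-out lower numbers stand for an effect already at smaller amounts and higher numbers for an effect only at larger amounts of compound), compound 3 gives 88 nM, the lowest of the three numbers measured so far; compound 1 sits at 460 nM and compound 2 at 1200 nM, both beyond the scatter from compound 3. The step of a 14-fold lower number from compound 2 to compound 3 (1.13 log units; beyond the scatter) shows how strongly a change on the ring that sits on the amide-type nitrogen can move the number.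

Compound 4, `O=C1CC(c2nc(-c3cccc(F)c3)no2)CN1c1ccc(Cl)c(Cl)c1`, has not been measured. It differs from compound 3 by 3,4-dichlorophenyl in place of 4-fluorophenyl on an amide-type nitrogen in a ring. Among the compounds with values here, no measured step covers exactly this change. Compound 1 carries the same 3,4-dichlorophenyl group, but it also differs from compound 4 on the other aromatic ring, so it only hints at the region where compound 4 might fall. The value of compound 1, 460 nM, lies clearly above that of compound 3, which is the basis for expecting the step of a 3.4-fold higher number from compound 3 to compound 4 (0.53 log units; beyond the scatter) toward a higher number in this assay. The estimate for compound 4 is therefore 300 nM, with a range from 80 nM to 1200 nM, reflecting how little the existing steps constrain this particular change.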

Compound 4, half-maximal effective concentration: 3200 nM
For compound 4 the middle estimate is 11-fold (1.03 log units) below the measured one, outside the stated range (above it).
By their numbers in this assay, from the lowest: compound 3; then compound 1; then compound 2; then compound 4.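

In this assay, the change from 4-fluorophenyl to 3,4-dichlorophenyl on the amide-type nitrogen is a large one, a 36-fold higher number from compound 3 to compound 4 (1.56 log units; beyond the scatter), and the 3,4-dichlorophenyl group also falls behind 4-methylphenyl, with a 2.7-fold higher number from compound 2 to compound 4 (0.43 log units; beyond the scatter), so this position separates these three groups widely while the rest of the structure stays the same. The other aromatic ring proves to matter as well: with 3,4-dichlorophenyl held constant, fluoro in place of chloro gives a 7.0-fold higher number from compound 1 to compound 4 (0.84 log units; beyond the scatter), whereas fluoro in place of methyl on the nitrogen-bound ring in the earlier step lowered the number, so the same halogen swap-in does not move the number in one direction across the two places. Nothing measured alongside these numbers accounts for either step.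

Going by these compounds, it remains open whether one chlorine alone on the nitrogen-bound ring, or the pair together, accounts for the rise, and how an unsubstituted phenyl would compare. Also open, on these data alone, is how a methoxy group or a trifluoromethyl group on that ring would fare, and whether the effect of the ring on the other side holds for the 4-fluorophenyl compounds too.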